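The source may hold more compounds than are shown below. What is called first, only, known or untested is meant among the compounds shown, and "the series" means these compounds.

In an assay on Cerebral cortex for displacement of a labelled ligand from adenosine receptor A1 (Bos taurus) (a higher number here means a weaker inhibitor, a lower number a stronger inhibitor), compound 1 `CNc1nc(-c2ccccc2)nc2c1nnn2Cc1ccccc1` gives 353 nM, compound 2 `CCNc1nc(-c2ccccc2)nc2c1nnn2Cc1ccccc1` gives 91 nM, and compound 3 `CCCCCCNc1nc(-c2ccccc2)nc2c1nnn2Cc1ccccc1` gives 13.2 nM, the lowest of the three numbers. The steps that lead there are a 3.9-fold lower number from compound 1 to compound 2 (0.59 log units; beyond the scatter), a 27-fold lower number from compound 1 to compound 3 (1.43 log units; beyond the scatter) and a 6.9-fold lower number from compound 2 to compound 3 (0.84 log units; beyond the scatter); each adds carbon to the chain on the nitrogen on the aromatic ring, and each lowers the number. Compound 4 `c1ccc(Cn2nnc3c(NC4CCC4)nc(-c4ccccc4)nc32)cc1` differs from compound 3 by cyclobutyl in place of hexyl on a nitrogen on an aromatic ring, a ring in place of a chain. For the measured compounds named here, no measured step swaps a chain for a ring, so the expectation rests on the chain steps alone and carries real uncertainty. For compound 4 the expected value is 22 nM, with a range from 6 nM to 80 nM, which means an expected step of a 1.7-fold higher number from compound 3 to compound 4 (0.22 log units; within the scatter).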

Compound 4, inhibition constant: 5 nM
Estimate against measurement, compound 4: 4.4-fold (0.64 log units) above; the measured number lies below the stated range.
By their numbers in this assay, from the lowest: compound 4; then compound 3; then compound 2; then compound 1.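

At this nitrogen on an aromatic ring, the earlier rule of more chain carbon meaning a lower number is not the only route: cyclobutyl has fewer carbons than hexyl, yet this assay gives a 2.6-fold lower number from compound 3 to compound 4 (0.42 log units; beyond the scatter). Against the shorter chains the drop is larger, with an 18-fold lower number from compound 2 to compound 4 (1.26 log units; beyond the scatter) and a 71-fold lower number from compound 1 to compound 4 (1.85 log units; beyond the scatter). No available evidence bears on why the ring does better. The compounds shown leave open whether ring size matters here, which cyclopropyl, cyclopentyl or cyclohexyl on the same nitrogen would test.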